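The source may report more compounds than this note shows. Statements on the series, on what has been measured and on what is new or still open speak of the compounds shown alone.

Measured in an ADME assay on HEp-2 cells (Homo sapiens) for cytotoxicity, read by MTT assay, with a stated time of 3 days; a lower number here means that less compound is tolerated, a higher number that more compound is tolerated:
compound 1 `Clc1ccc([C@@H](CCn2cncn2)Cc2ccccc2)cc1` — 25.9 ug/mL
compound 2 `Clc1ccc([C@H](CCn2cncn2)Cc2ccccc2)cc1` — 25.7 ug/mL

Of the two numbers shown, compound 1 is not separated from compound 2: the step of a 1.0-fold lower number from compound 1 to compound 2 (0.00 log units; within the scatter) lies within the scatter. The two compounds share all atoms and bonds and differ only in how the stereocentre is drawn (the fact that compounds 1 and 2 differ only in the configuration as drawn), so this pair says only that the drawn configuration at that carbon leaves the read-out unchanged.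

Compound 3 `C[C@@H](CCn1cncn1)Cc1ccccc1` has not yet been measured in this assay. It differs from compound 1 by methyl in place of 4-chlorophenyl on a saturated chain carbon bound to two saturated chain carbons. Within the data shown here, the single measured step, a 1.0-fold lower number from compound 1 to compound 2 (0.00 log units; within the scatter), concerns a change of configuration alone and does not bear on an exchange of a ring for a methyl at that carbon; no measured pair in this set makes such an exchange. Among the measured compounds shown here, there is thus no measured step from which to size the change, and its direction is open. The expected step is a 1.5-fold higher number from compound 1 to compound 3 (0.19 log units; within the scatter), carried with a wide range. For compound 3 the estimate in this assay is 40 ug/mL, with a range from 15 ug/mL to 110 ug/mL.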

Compound 3, half-maximal cytotoxic concentration: 131 ug/mL
Beside the measured number, compound 3's estimate is 3.3-fold (0.52 log units) below it; measured number above the stated range.
By their numbers in this assay, from the lowest: compounds 2 and 1 (each within the scatter of the next); then compound 3.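

In this assay, the saturated chain carbon bound to two saturated chain carbons responds to the group it carries, which the configuration pair could not show: the exchange of 4-chlorophenyl for methyl gives a 5.1-fold higher number from compound 1 to compound 3 (0.70 log units; beyond the scatter). Among these compounds, this is the first step beyond the scatter, and it points towards more compound being tolerated with methyl at this carbon than with 4-chlorophenyl. The step removes the ring and the chlorine together, so it cannot separate the share of either, and nothing on record bears on a cause for it.

The compounds shown leave open whether the drawn configuration at this carbon still leaves the read-out unchanged when methyl is the group there. Also open, going by these compounds, is how an unsubstituted phenyl, a longer chain such as propyl, or an amine at the same carbon would read in this assay, and so whether the number rises in step with the removal of the ring or depends on methyl itself.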